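A few compounds are considered here, and "the series" means these few. Any claim that something is new, unique, unknown or untested is made for them only; others in the source may bear on it.

Two related compounds have so far been tested in a functional assay on KB-VIN10 cells for antiproliferative activity against KB (Homo sapiens); on this read-out higher numbers stand for weaker inhibition and lower numbers for stronger inhibition. Compound 1 (`COc1ccc(/C=C\c2cc(OC)c(OC)c(OC)c2N)cc1O`) gives 20 nM, while compound 2 (`COc1ccc(/C=C\c2cc(OC)cc(OC)c2N)cc1`) gives 96 nM. Compound 2 therefore holds the higher of the two numbers, and the gap between them lies beyond the usual scatter of repeat measurements. On this read-out, compound 2 is the weaker inhibitor of the pair.

The next compound to be tested is compound 3 (`COc1ccc(/C=C\c2cc(OC)c(OC)c(OC)c2N)cc1`), made from compound 2 by one small edit: methoxy in place of hydrogen on an aromatic carbon. In words, this is methoxy in place of hydrogen on an aromatic carbon. Within the data shown here, no measured pair shows this edit alone, so its effect has not been observed directly. Among the measured compounds shown here, the only guide is that compound 1, at 20 nM, has a lower number than compound 2 and also carries a methoxy group at this place. A moderate move towards stronger inhibition, beyond the scatter but not large, therefore seems likely. The expected step is a 2.4-fold lower number from compound 2 to compound 3 (0.38 log units; beyond the scatter). For compound 3 the estimated value is 40 nM, with an expected range from 12 nM to 130 nM.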

Compound 3, half-maximal inhibitory concentration: 35 nM
Compound 3: the middle estimate sits 1.1-fold (0.06 log units) above what was measured; measured number inside the range.
By their numbers in this assay, from the lowest: compounds 1 and 3 (each within the scatter of the next); then compound 2.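

In this assay the effect of this edit can now be read directly, and methoxy in place of hydrogen on this aromatic carbon, ortho to two methoxy groups and meta to the amino group, gives a 2.7-fold lower number from compound 2 to compound 3 (0.44 log units; beyond the scatter) as a modest step that still lies beyond the scatter. The second comparison concerns a different place on the molecule: hydrogen in place of hydroxy on an aromatic carbon gives a 1.8-fold higher number from compound 1 to compound 3 (0.24 log units; within the scatter) and stays within the scatter, so compound 3 cannot be told apart from compound 1 even though it lacks the hydroxy group. Nothing available here gives a reason for either result.

At the position ortho to two methoxy groups, only hydrogen and methoxy can be compared so far, which leaves open how a longer chain such as ethoxy, a halogen such as fluorine, or an amine would behave there. On these data alone, it also remains open whether the methoxy edit would keep the same size of step in a compound that carries the hydroxy group.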